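This account rests on a few compounds, and the source may have more. Where it says the series, first, only, none or still open, it means among the compounds named here.

Measured compounds in an assay on microsomes from liver for inhibition of 3-hydroxy-3-methylglutaryl-coenzyme A reductase (Rattus norvegicus); on this read-out higher numbers stand for weaker inhibition and lower numbers for stronger inhibition:
compound 1, `CC(C)c1c(C(=O)NCC2CCCCC2)nn(-c2ccc(F)cc2)c1OC[C@@H](O)C[C@@H](O)CC(=O)O`: 17 nM
compound 2, `Cc1cccc(CNC(=O)c2nn(-c3ccc(F)cc3)c(OC[C@@H](O)C[C@@H](O)CC(=O)O)c2C(C)C)c1`: 4.9 nM
compound 3, `CC(C)c1c(C(=O)NCc2ccc(Cl)cc2)nn(-c2ccc(F)cc2)c1OC[C@@H](O)C[C@@H](O)CC(=O)O`: 6.7 nM

Among the three, compound 2 carries the smallest number; its gap to compound 3 is a 1.4-fold higher number from compound 2 to compound 3 (0.14 log units; within the scatter), so the two are not distinguished. The step of a 3.5-fold lower number from compound 1 to compound 2 (0.54 log units; beyond the scatter) and the parallel step a 2.5-fold lower number from compound 1 to compound 3 (0.40 log units; beyond the scatter) point the same way: a six-membered aromatic ring of carbon only in place of cyclohexyl lowers the number.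

Compound 4, `CC(C)c1c(C(=O)N(C)Cc2cccc(Cl)c2)nn(-c2ccc(F)cc2)c1OC[C@@H](O)C[C@@H](O)CC(=O)O`, is not yet measured. It differs from compound 2 in one place: (3-chlorobenzyl)(methyl)amino in place of (3-methylbenzyl)amino on a carbonyl carbon. Two things change at once. Chlorine in place of methyl on the ring has a near analogue in a 1.4-fold higher number from compound 2 to compound 3 (0.14 log units; within the scatter), which stayed within the scatter, so that part is expected to matter little. Among the measured compounds shown here, the methyl on the amide nitrogen, with loss of the single hydrogen-bond donor, has no precedent among the measured compounds; no measured step bears on it. The expectation therefore rests on the halogen part alone, with widened uncertainty for the untested methyl.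

The expected step is a 1.4-fold higher number from compound 2 to compound 4 (0.15 log units; within the scatter), small and not beyond the scatter. Compound 4 is estimated at 7 nM, within 2.5 nM to 20 nM.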

Compound 4, half-maximal inhibitory concentration: 8.3 nM
Estimate against measurement, compound 4: 1.2-fold (0.07 log units) below; the measured number falls inside the stated range.
By their numbers in this assay, from the lowest: compounds 2, 3 and 4 (each within the scatter of the next); then compound 1.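

In this assay the amide hydrogen on the carbonyl carbon proves dispensable in this set: with (3-chlorobenzyl)(methyl)amino in place, a 1.7-fold higher number from compound 2 to compound 4 (0.23 log units; within the scatter) and a 1.2-fold higher number from compound 3 to compound 4 (0.09 log units; within the scatter) both stay within the scatter, so compound 4 is not distinguished from either secondary amide. The gain over the cyclohexyl-bearing amide also persists without that hydrogen, since a 2.0-fold lower number from compound 1 to compound 4 (0.31 log units; beyond the scatter) lies beyond the scatter and compounds 2, 3 and 4 all sit on the same side of compound 1, with none of the four going against this. Nothing available accounts for this tolerance of the added methyl or for the preference for the aromatic ring over cyclohexyl.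

All three steps change the amide nitrogen and the ring or its substituent together, so the share of the methyl alone stays unresolved; the direct partner, (3-chlorobenzyl)amino on the same carbonyl carbon, is absent from the compounds shown. Also open, from the compounds shown here alone, is how far the nitrogen accepts more than a methyl, for example an ethyl group, a longer chain, or a chain ending in an amine or a carboxylic acid.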